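Swapping methyl for chloro on the benzyl sulfur substituent

The source may hold more compounds than are shown below. What is called first, only, known or untested is meant among the compounds shown, and "the series" means these compounds.

Measured so far in a functional assay on DU-145 cells (Homo sapiens) for inhibition, read by trypan blue exclusion, with a stated time of 96 h; on this read-out higher numbers stand for weaker inhibition of growth and lower numbers for stronger inhibition of growth

- compound 1 `Cc1ccc(C)c(/C=C(/Sc2ccc(Br)cc2)C(=O)c2ccc(Cl)cc2)c1` gives 10000 nM
- compound 2 `O=C(/C(=C\c1ccc(O)cc1O)SCc1ccc(Cl)cc1)c1ccc(Cl)cc1` gives 50000 nM
- compound 3 `Cc1ccc(CS/C(=C/c2cc(C)ccc2C)C(=O)c2ccc(Cl)cc2)cc1` gives 10000 nM

Compound 3 stands level with compound 1 (10000 nM) and the two share the lowest number of the three. Compound 2 (50000 nM) lies higher, beyond the scatter.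

Compound 4 `Cc1ccc(C)c(/C=C(/SCc2ccc(Cl)cc2)C(=O)c2ccc(Cl)cc2)c1` has chloro in place of methyl on an aromatic carbon and so carries 4-chlorobenzyl instead of 4-methylbenzyl. Among the compounds with values here, only one measured step touches this sulfur substituent, 4-methylbenzyl in place of 4-bromophenyl, and it reads no change at the digits printed from compound 1 to compound 3 (within the scatter) in this series. Within the data shown here, compound 2 also carries 4-chlorobenzyl, yet no measured step isolates that group. With so little evidence, and that step showing nothing, no move in either direction is expected in this assay beyond the scatter. The expected step is no change at the digits printed from compound 3 to compound 4 (within the scatter) on this reasoning. The estimate for compound 4 is 10000 nM with an expected range from 4000 nM to 25000 nM for the coming measurement.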

Compound 4, concentration for 50% growth inhibition: 10000 nM
Estimate against measurement, compound 4: no gap at the digits printed; the measured number falls inside the stated range.
By their numbers in this assay, from the lowest: compounds 1, 3 and 4 (each within the scatter of the next); then compound 2.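

In this assay chloro in place of methyl on an aromatic carbon, para to a large group, gives no change at the digits printed from compound 3 to compound 4 (within the scatter) and a change of the sulfur substituent alone gives no change at the digits printed from compound 1 to compound 4 (within the scatter), so the 4-methylbenzyl, 4-chlorobenzyl and 4-bromophenyl sulfur substituents read alike with 2,5-dimethylphenyl held fixed. Within the data shown here, with 4-chlorobenzyl held fixed, 2,5-dimethylphenyl in place of 2,4-dihydroxyphenyl gives a 5.0-fold lower number from compound 2 to compound 4 (0.70 log units; beyond the scatter), the only step so far beyond the scatter, and it falls on the aryl group rather than on the sulfur substituent. Nothing available explains the size of any of these steps.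

Still open, as far as these compounds go, is whether an amine or a carboxylic acid in the place of this chloro would also read alike. Also open, from the compounds shown here alone, is whether a single hydroxy group on the aryl ring would read as the 2,4-dihydroxyphenyl group does.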